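This account rests on a few compounds, and the source may have more. Where it says the series, first, only, none or still open, it means among the compounds named here.

Compound 2 `COc1cc(C)c(S(=O)(=O)N(C)CCOCC(=O)N2CCC(C3CCN(C)CC3)CC2)c(C)c1` gives 0.7 nM in an assay on HEK293 cells for displacement of a labelled ligand from B1 bradykinin receptor (Homo sapiens), read by scintillation counting (on this read-out lower numbers stand for stronger inhibition and higher numbers for weaker inhibition), and stands lowest of the three measured numbers. Compound 1 `Cc1c(Cl)ccc(S(=O)(=O)N(C)CCOCC(=O)N(C)Cc2ccc(C3=NCCN3)cc2)c1Cl` gives 2.1 nM in this assay, and compound 3 `CN(Cc1ccc(C2=NCCN2)cc1)C(=O)COCCN(C)S(=O)(=O)c1c(F)cccc1F` gives 142 nM. Among the compounds with values here, the only single-point step measured so far, a 68-fold higher number from compound 1 to compound 3 (1.83 log units; beyond the scatter), concerns the aryl group on the sulfonyl sulfur and not the amine end of the molecule. Compound 4 `COc1cc(C)c(S(=O)(=O)N(C)CCOCC(=O)N2CCC(C3CCN(C(C)C)CC3)CC2)c(C)c1` differs from compound 2 by isopropyl in place of methyl on an amine nitrogen in a ring. No measured step touches this nitrogen, so nothing shown bears on the change directly. With no ground for a shift in either direction, a step of a 1.4-fold higher number from compound 2 to compound 4 (0.15 log units; within the scatter) is expected, within the scatter. Compound 4 is therefore estimated at 1 nM in this assay, with a range from 0.3 nM to 3.5 nM.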

Compound 4, inhibition constant: 0.4 nM
For compound 4 the middle estimate is 2.5-fold (0.40 log units) above the measured one, within the range that was stated.
By their numbers in this assay, from the lowest: compounds 4 and 2 (each within the scatter of the next); then compound 1; then compound 3.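

In this assay the first step measured at this amine nitrogen in a ring, a 1.8-fold lower number from compound 2 to compound 4 (0.24 log units; within the scatter), lies within the scatter, so isopropyl and methyl cannot be told apart here. The nitrogen of this pair therefore tolerates the larger alkyl group, whereas the aryl group on the sulfonyl sulfur gives a step beyond the scatter, a 68-fold higher number from compound 1 to compound 3 (1.83 log units; beyond the scatter). No supporting data offer an explanation for this result. Open, going by these compounds, is how a hydrogen, a benzyl group or a longer chain bearing a carboxylic acid on this nitrogen would read. Also open, on these data alone, is whether this tolerance extends to other aryl sulfonyl groups.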